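The source may hold more compounds than are shown below. What is called first, only, known or untested is meant among the compounds shown, and "the series" means these compounds.

Measured so far:
- Compound 1, `Cc1ccc(N(C)C(=O)c2c(-c3ccccc3)nnc3ccccc23)cc1C` — in an assay for binding affinity to CDK8/Cyclin C (Homo sapiens), read by FRET and LanthaScreen, with stated times of 20 min and 2 h, tested at 10 uM (on this read-out lower numbers stand for less inhibition and higher numbers for more inhibition at the one concentration tested (going by the name of the read-out)), compound 1 gives 16%
- Compound 2, `CCOc1ccc(C(=O)c2cnc3ccc(F)cc3c2N2CCCC2)cc1` — in this assay compound 2 gives 50%

Going by the values given here, only two compounds have a number, and they differ in many places, so the gap between them says nothing about any single change. Compound 2 stands highest of the two; its nearest neighbour is compound 1, whose number lies well lower, beyond the usual scatter of such repeated measurements.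

The next compound, compound 3, `CCOc1ccc(C(=O)c2cnc3ccc(Cl)cc3c2N2CCCC2)cc1`, is built from compound 2 by a single exchange:

chloro in place of fluoro on an aromatic carbon

The new group sits on an aromatic carbon of a six-membered aromatic ring of carbon only, part of a fused or bridged system of two rings. Nothing measured here shows what this exchange does in this assay, so the expectation rests on the size of the change alone: one atom for one atom, with no ring, no donor or acceptor and no charge gained or lost. A step of about a number 5 percentage points higher from compound 2 to compound 3 (within the scatter) is expected, which is within the scatter, in other words no clear movement in either direction. For compound 3 the estimate in this assay is therefore 55%, with a range from 30% to 80%.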

Compound 3, a percentage reported as inhibition, at one concentration (the size of the read-out at that concentration, not a potency): 46%
The estimate for compound 3 lay 9 percentage points above the measured number, and the stated range covers the measured number.
By their numbers in this assay, from the lowest: compound 1; then compounds 3 and 2 (each within the scatter of the next).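

Going by these compounds alone, compounds 2 and 3 are the first pair here that differ in only one place, so this step can be read on its own, unlike the gap between the two earlier compounds. In this assay, putting chloro in place of fluoro on an aromatic carbon of the six-membered aromatic ring of carbon only gives a number 4 percentage points lower from compound 2 to compound 3 (within the scatter) and shows no clear movement, so at this position and at this single test concentration, the two groups cannot be told apart. Nothing measured here offers an explanation for this result.

Fluoro and chloro are both single atoms with no ring, no hydrogen-bond donor or acceptor and no net charge, so the pair leaves open how this same carbon would respond to a different kind of group, such as an amine, a nitrile or a methoxy group, or to plain hydrogen. It also leaves open how changes elsewhere on the shared core would behave, and which of the many differences between compound 1 and the other two compounds matter.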